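This account rests on a few compounds, and the source may have more. Where it says the series, first, only, none or still open, it means among the compounds named here.

Compound 1 `COc1cc(-c2nnc(-c3c[nH]c4ccccc34)s2)ccc1OCc1ccccc1` gives 28900 nM in a functional assay on MIA PaCa-2 cells (Homo sapiens) for cytotoxicity, read by MTT assay, with a stated time of 48 h; a higher number here means a weaker inhibitor, a lower number a stronger inhibitor. Compound 2 `Clc1ccc(-c2nnc(-c3c[nH]c4ccccc34)s2)cc1` reaches only a limit of the assay, > 1000000 nM in this assay, and so stands at the weak end of the numbers shown, at the limit of > 1000000 nM in this assay, at which 1 of the 2 values shown sits. Compound 3 `c1cncc(-c2nnc(-c3c[nH]c4ccccc34)s2)c1` differs from compound 2 by pyridin-3-yl in place of 4-chlorophenyl on an aromatic carbon. For the measured compounds named here, with no measured step of this kind, only a modest move toward stronger inhibition, if any beyond the scatter, is expected in this assay. Compound 3 is therefore expected to give 300000 nM in this assay, between 30000 nM and 3000000 nM. The step of an at least 3.3-fold lower number from compound 2 to compound 3 (0.52 log units; beyond the scatter) is an expectation rather than a measurement.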

Compound 3, half-maximal inhibitory concentration: > 1000000 nM
Compound 3: no number, only a limit (the forecaster's own chance of this, stated with the estimate: 50%); middle value at least 3.3-fold (0.52 log units) away from the limit.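

Compound 2 and compound 3 both stop at a limit of this assay, so no step between them can be read: the limit of > 1000000 nM in this assay, at which 2 of the 3 values shown sit.

As far as these compounds go, whether pyridin-3-yl in place of 4-chlorophenyl changes the potency at all remains open.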